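A few compounds are considered here, and "the series" means these few. Any claim that something is new, unique, unknown or untested is made for them only; others in the source may bear on it.

Measured so far:
- compound 1 `Cc1cccc(CN2CCN(C(=O)CN[C@H]3CCN(S(=O)(=O)Cc4ccccc4)C3)CC2)c1` gives 11300 nM
- compound 2 `Cc1ccc(CN2CCN(C(=O)CN[C@H]3CCN(S(=O)(=O)Cc4ccccc4)C3)CC2)cc1` gives 8200 nM
- compound 3 `O=C(CN[C@H]1CCN(S(=O)(=O)Cc2ccccc2)C1)N1CCN(Cc2ccccc2Cl)CC1` gives 9000 nM

All three values come from a functional assay on K562 cells (Homo sapiens) for cytotoxicity, read by MTT assay, with a stated time of 48 h; on this read-out lower numbers stand for stronger inhibition and higher numbers for weaker inhibition. Compound 1 sits within the scatter of both neighbours, so the three compounds form one flat group, and no order can be read among them.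

Compound 4 `O=C(CN[C@H]1CCN(S(=O)(=O)Cc2ccccc2)C1)N1CCN(Cc2ccc(Cl)cc2)CC1` is not yet measured. The change is 4-chlorophenyl in place of 3-methylphenyl on a saturated chain carbon bound to an amine nitrogen in a ring, in words 4-chlorophenyl in place of 3-methylphenyl on a saturated chain carbon bound to an amine nitrogen in a ring.

Within the data shown here, three measured steps bear on it, all at this same place: a 1.4-fold lower number from compound 1 to compound 2 (0.14 log units; within the scatter), a 1.3-fold lower number from compound 1 to compound 3 (0.10 log units; within the scatter) and a 1.1-fold higher number from compound 2 to compound 3 (0.04 log units; within the scatter). Each stays within the scatter. Compound 2 already carries a 4-substituted ring and compound 3 a chlorophenyl, so compound 4 combines features seen in these two. No step beyond the scatter is therefore expected, and the expected step is a 1.3-fold lower number from compound 1 to compound 4 (0.12 log units; within the scatter).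

The estimate for compound 4 is 8500 nM, with an expected range of 4500 nM to 15000 nM.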

Compound 4, half-maximal inhibitory concentration: 9200 nM
For compound 4 the middle estimate is 1.1-fold (0.03 log units) below the measured one; the measured number falls inside the stated range.
By their numbers in this assay, from the lowest: compounds 2, 3, 4 and 1 (each within the scatter of the next).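

In this assay the change to 4-chlorophenyl gives a 1.2-fold lower number from compound 1 to compound 4 (0.09 log units; within the scatter) and so leaves the series flat, even with the 4-substitution and the chlorine on one ring at this place. Moving the chlorine gives a 1.0-fold higher number from compound 3 to compound 4 (0.01 log units; within the scatter) and chloro in place of methyl on an aromatic carbon gives a 1.1-fold higher number from compound 2 to compound 4 (0.05 log units; within the scatter), so neither change separates these compounds. No measurement at hand offers an explanation for this flatness.

Going by these compounds, all four compounds carry a phenyl with a methyl or chloro group, so it remains open whether an amine, a carboxylic acid or a methoxy group on that phenyl, or a longer chain at this place, would give a step beyond the scatter. Changes elsewhere in the core of compound 1 also remain open.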